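The source may report more compounds than this note shows. Statements on the series, on what has been measured and on what is new or still open speak of the compounds shown alone.

Compound 3, `CCCCCCCCCCCOc1ccccc1CCC(=O)O[C@@H]1CCOC[C@@H]1OP(=O)(O)OC[C@H](N)C(=O)O`, gives 19.3% in an assay on HEK293 cells for agonist activity at putative P2Y purinoceptor 10 (Mus musculus), with a stated time of 1 h (a higher number here means a larger maximal response, a lower number a smaller maximal response), the highest of the two numbers recorded here; compound 2, `CCCCCCCCCCCOc1ccccc1CCC(=O)O[C@H]1CCOC[C@H]1OP(=O)(O)OC[C@H](N)C(=O)O`, gives 3.2% in this assay, and compound 1, `CCCCCCCC/C=C\CCCCCCCC(=O)OC[C@@H](COCC)OP(=O)(O)OC[C@H](N)C(=O)O`, is "not active" (no number reported) in this assay. Compound 4, `CCCCCCCCCCCOc1ccccc1CCC(=O)O[C@@H]1CCOC[C@H]1OP(=O)(O)OC[C@H](N)C(=O)O`, keeps every atom and bond of compound 3 and differs only in drawn stereochemistry: the two compounds have the same atoms and bonds; at least one stereo element is drawn with a configuration in one of them and without one in the other: 1 of 4 stereo elements differ; a stereocentre at a saturated ring carbon is drawn S in compound 3 and R in compound 4. Within the data shown here, the single measured step that bears on this, a number 16.1 percentage points higher from compound 2 to compound 3 (beyond the scatter), likewise changed only configuration, but at two ring centres at once, and the only hint bearing on its cause is the fact that one of compounds 2 and 3 is drawn with a defined configuration and the other without, at the place where they differ. A change at one ring centre is expected to move the maximal response by a comparable or smaller amount, more likely downward. Compound 4 is estimated at 10%, between 2% and 25%. This implies an expected step of a number 9.3 percentage points lower from compound 3 to compound 4 (within the scatter).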

Compound 4, largest response reached (Emax), in percent of the reference or control that the assay uses: 10.6%
Compound 4: middle estimate off by 0.6 percentage points, on the low side; the range from low to high includes it.
By their numbers in this assay, from the lowest: compounds 2, 4 and 3 (each within the scatter of the next, the first and the last beyond it).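

In this assay the single-centre changes give a number 8.7 percentage points lower from compound 3 to compound 4 (within the scatter) and a number 7.4 percentage points higher from compound 2 to compound 4 (within the scatter) here, so neither ring centre alone moves the maximal response past the usual scatter. Only changing both centres together, a number 16.1 percentage points higher from compound 2 to compound 3 (beyond the scatter) in all, clears that scatter, and the earlier pair could not separate this joint change from the effect of one centre. Still open, going by these compounds, is whether a shorter chain in place of the long ether chain, or an amide in place of the ester, would raise the maximal response.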